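Methoxy to hydroxy on a cytotoxic enone series

The compounds below may be only part of what the source reports. "The series", "measured", "known", "first", "only" and "open" are said of these compounds alone.

Measured so far in a functional assay on PC-3 cells (Homo sapiens) for cytotoxicity, read by MTT assay, with a stated time of 72 h; a higher number here means a weaker inhibitor, a lower number a stronger inhibitor:
compound 1 `COc1ccc(/C=C/C(=O)CC(C)=O)cc1OC` gives 8900 nM
compound 2 `COc1ccc(/C=C/C(=O)CC(C)=O)cc1` gives 15800 nM
compound 3 `CC(=O)CC(=O)/C=C/c1ccc(O)cc1` is still to be measured

Compound 2, at 15800 nM, stands within the scatter of compound 1, so the two numbers set no real order between them. Compound 3 differs from compound 2 by one small edit (hydrogen in place of methyl on an oxygen on an aromatic ring), which is hydrogen in place of methyl on an oxygen on an aromatic ring, or methoxy to hydroxy.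

Within the data shown here, only one measured step bears on this, and only indirectly. It is a 1.8-fold higher number from compound 1 to compound 2 (0.25 log units; within the scatter), where hydrogen replaces a whole methoxy on an aromatic carbon rather than only its methyl. Among the measured compounds shown here, no compound measured so far carries a hydroxy group, so the expectation rests on that single step and stays wide. No step beyond the scatter is expected in this assay, though neither direction can be ruled out. The expected change is a 1.3-fold lower number from compound 2 to compound 3 (0.12 log units; within the scatter) as an estimate. Compound 3 is estimated at 12000 nM with an expected range from 5000 nM to 30000 nM around it.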

Compound 3, half-maximal inhibitory concentration: 20200 nM
For compound 3 the middle estimate is 1.7-fold (0.23 log units) below the measured one; measured number inside the range.
By their numbers in this assay, from the lowest: compounds 1, 2 and 3 (each within the scatter of the next, the first and the last beyond it).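

Among these compounds, this is the first free hydroxy group, and in this assay putting hydrogen in place of methyl on the oxygen on the aromatic ring gives a 1.3-fold higher number from compound 2 to compound 3 (0.11 log units; within the scatter) and so sets no real order between the two compounds. The methoxy at this place can therefore give up its methyl without a step beyond the scatter, in this one pair on this core, a different edit from the earlier one that gave a 1.8-fold higher number from compound 1 to compound 2 (0.25 log units; within the scatter) by replacing a whole methoxy with hydrogen. Nothing given here explains why the number holds or bears on what the methyl or the hydroxy does in these cells.

The compounds shown leave open whether a larger group on the same oxygen, such as ethoxy or a longer chain, or an amine or a carboxylic acid in place of the hydroxy, would read beyond the scatter. They also leave open whether the same methoxy to hydroxy edit would read the same way on the core of compound 1, which carries a second methoxy.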